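Ring size at the chain amine: piperidinyl to pyrrolidinyl

This account rests on a few compounds, and the source may have more. Where it says the series, first, only, none or still open, it means among the compounds named here.

Compound 3 `COc1cc2c(Nc3nc4ccc(C(=O)Nc5c(C)cc(C)cc5C)cc4s3)ncnc2cc1OCCCN1CCCCC1` gives 9300 nM in a functional assay on K562 cells (Homo sapiens) for cytotoxicity, read by WST assay, with a stated time of 72 h (on this read-out higher numbers stand for weaker inhibition and lower numbers for stronger inhibition), the middle of three numbers that all lie within the scatter of one another. For the measured compounds named here, compound 1 `COc1cc2c(Nc3nc4ccc(C(=O)Nc5c(C)cc(C)cc5C)cc4s3)ncnc2cc1OCCCN1CCC(C)CC1` gives 5900 nM in this assay, and the only single-point step measured so far, a 1.6-fold higher number from compound 1 to compound 3 (0.20 log units; within the scatter), stays within the scatter. Compound 2 `COc1cc2c(Nc3nc4ccc(C(=O)Nc5c(C)cccc5C)cc4s3)ncnc2cc1OCCCN1CCCC1` gives 15700 nM in this assay; it already carries the pyrrolidinyl ring, but it also differs from compound 3 at the amide aryl group, so no clean step can be read from it, and its value and that of compound 3 are within the scatter of each other.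

Compound 4 `COc1cc2c(Nc3nc4ccc(C(=O)Nc5c(C)cc(C)cc5C)cc4s3)ncnc2cc1OCCCN1CCCC1` differs from compound 3 by pyrrolidin-1-yl in place of piperidin-1-yl on a saturated chain carbon, three bonds along the chain from an oxygen on an aromatic ring. Going by the values given here, no measured step bears directly on this change. Every step seen in the series is within the scatter, and compound 2, with the same amine ring, shows a value in the same region; the expected step of a 1.1-fold higher number from compound 3 to compound 4 (0.05 log units; within the scatter) is therefore none beyond the scatter. Compound 4 is estimated at 10500 nM in this assay, with a range from 4500 nM to 25000 nM.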

Compound 4, half-maximal inhibitory concentration: 4300 nM
Compound 4: the middle estimate sits 2.4-fold (0.39 log units) above what was measured; the measured number lies below the stated range.
By their numbers in this assay, from the lowest: compounds 4, 1, 3 and 2 (each within the scatter of the next, the first and the last beyond it).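

For the compounds shown here, at the saturated chain carbon, three bonds along the chain from an oxygen on an aromatic ring, pyrrolidin-1-yl in place of piperidin-1-yl gives the first change at this position that lies beyond the scatter in this assay, with a 2.2-fold lower number from compound 3 to compound 4 (0.34 log units; beyond the scatter). Set against 4-methylpiperidin-1-yl at the same place, pyrrolidin-1-yl gives a 1.4-fold lower number from compound 1 to compound 4 (0.14 log units; within the scatter), which stays within the scatter, so the gain over the unsubstituted six-membered ring is modest and does not separate the two best-placed amines. With pyrrolidin-1-yl held fixed, methyl in place of hydrogen on an aromatic carbon gives a 3.7-fold lower number from compound 2 to compound 4 (0.56 log units; beyond the scatter), so the amide aryl group also counts in this series.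

Open, as far as these compounds go, is how morpholin-4-yl, dimethylamino or a longer chain would read at this position. No measurement shown here accounts for these steps.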